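This account rests on a few compounds, and the source may have more. Where it says the series, first, only, none or still open, it means among the compounds named here.

Working notes on the series.

Of the compounds shown here, two have been measured in a functional assay on HeLa cells (Homo sapiens) for inhibition, read by MTT assay, with a stated time of 72 h; a higher number here means a weaker inhibitor, a lower number a stronger inhibitor. Compound 1 `N[C@H](CSCC(=O)Nc1c[nH]c(=O)[nH]c1=O)C(=O)O` gives 86000 nM in this assay. Compound 2 `O=c1nc(NO)cc[nH]1` is reported in this assay only as > 100000 nM, which is a limit of the assay and not a number. Compound 2 therefore sits at the limit of > 100000 nM in this assay, at which 1 of the 2 values shown sits, so its position on the scale is known only as a bound. Among the measured compounds shown here, no pair of measured compounds differs in a single place, and compound 1 and compound 2 have different cores, so the two values only show that one gives a number and the other a limit.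

Compound 3 `CSc1cc[nH]c(=O)n1` is not yet measured in this assay. It differs from compound 2 as follows: methylsulfanyl in place of hydroxyamino on an aromatic carbon; in words, methylsulfanyl in place of hydroxyamino on an aromatic carbon of the shared core of compound 2. For the measured compounds named here, with compound 2 known only as a limit, no step of a measurable size is expected in this assay; the expectation is that compound 3 stays at or around the limit, and the step from compound 2 to compound 3 is estimated as a step that the limit leaves unreadable from compound 2 to compound 3. For compound 3 the estimate in this assay is 150000 nM, with an expected range from 40000 nM to 600000 nM.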

Compound 3, half-maximal inhibitory concentration: > 100000 nM
Compound 3 gave a limit, no number; the forecaster's own chance of this, stated with the estimate: 75%; the middle value is on the limit's open side.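

Compound 3 is reported in this assay only as > 100000 nM, which is a limit of the assay and not a number. Compound 2 is also known only as a limit, so the step between compound 2 and compound 3 cannot be read. The compounds shown leave open whether any group at this place on the shared core gives a measurable value in this assay.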